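The compounds below may be only part of what the source reports. "The series", "measured", "known", "first", "only" and "open" are said of these compounds alone.

Series notes. Compound 1 `Cn1ncc(Cl)c1-c1cc(C(=O)N[C@@H]2CN[C@H](CC(=O)NC3CC3)C[C@H]2c2ccc(Cl)c(Cl)c2)oc1Cl` and compound 2 `CNC(=O)C[C@@H]1C[C@@H](c2ccc(F)c(F)c2)[C@H](NC(=O)c2cc(-c3c(Cl)cnn3C)c(Cl)o2)CN1` have been measured in a functional assay on OVCAR-8 cells (Homo sapiens) for antiproliferative activity; on this read-out lower numbers stand for stronger inhibition and higher numbers for weaker inhibition. Compound 1 gives 580 nM, the lower of the two numbers recorded, while compound 2 gives 800 nM; the gap between them is within the scatter of this assay, so nothing is read into it. Among the measured compounds shown here, compound 2 also differs from compound 1 in more than one place, so no single step is drawn between them. Compound 3 `Cn1ncc(Cl)c1-c1cc(C(=O)N[C@@H]2CN[C@H](CC(N)=O)C[C@H]2c2ccc(Cl)c(Cl)c2)oc1Cl` is not yet measured. It differs from compound 1 in one place only: hydrogen in place of cyclopropyl on an amide-type nitrogen. For the measured compounds named here, no measured pair isolates this change. Given the small size of the alteration, a modest move toward weaker inhibition, not clearly beyond the scatter, is expected for the step of a 1.5-fold higher number from compound 1 to compound 3 (0.17 log units; within the scatter) in this assay. Compound 3 is accordingly estimated at 850 nM, with a range from 300 nM to 2400 nM.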

Compound 3, half-maximal inhibitory concentration: 1000 nM
For compound 3 the middle estimate is 1.2-fold (0.07 log units) below the measured one; low and high end bracket the measured number.
By their numbers in this assay, from the lowest: compounds 1, 2 and 3 (each within the scatter of the next).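

In this assay hydrogen in place of cyclopropyl on an amide-type nitrogen gives a 1.7-fold higher number from compound 1 to compound 3 (0.24 log units; within the scatter). Among the compounds shown here, this is the first pair to isolate a change at this position, and it shows that the cyclopropyl group can be lost with no shift beyond the scatter. The read-out therefore gives no sign here that this assay requires the cyclopropyl group on this nitrogen, and no measurement at hand bears on why the two compounds read alike. From the compounds shown here alone, whether the same holds for a longer chain on this nitrogen, or for a carboxylic acid or an amine in place of the carbamoyl, remains open. Going by these compounds, the step has also been read only on the core of compound 1, so its size on other members is unknown.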